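This account rests on a few compounds, and the source may have more. Where it says the series, first, only, none or still open, it means among the compounds named here.

Compound 1 `[N-]=[N+]=Nc1ccc(-c2ccc(/C=C3/C(=O)N(c4ccc(Cl)c(C(=O)O)c4)N=C3C(F)(F)F)o2)cc1` gives 17300 nM
Compound 2 `O=C(O)c1cc(N2N=C(C(F)(F)F)/C(=C/c3ccc(-c4ccccc4)o3)C2=O)ccc1Cl` gives 14700 nM

Among the compounds with values here, in a functional assay on MM1.S cells (Homo sapiens) for cytotoxicity, read by MTT assay, with a stated time of 72 h (a higher number here means a weaker inhibitor, a lower number a stronger inhibitor), compound 1 at 17300 nM and compound 2 at 14700 nM lie within the usual scatter of each other, so compound 1 cannot be told apart from the only other compound measured. Compound 3 `[N-]=[N+]=Nc1cccc(-c2ccc(/C=C3/C(=O)N(c4ccc(Cl)c(C(=O)O)c4)N=C3C(F)(F)F)o2)c1` has the same atoms as compound 1, joined differently: 3-azidophenyl in place of 4-azidophenyl (3-azidophenyl in place of 4-azidophenyl on an aromatic carbon) on an aromatic carbon of a five-membered aromatic ring with 1 oxygen, next to the ring oxygen. Within the data shown here, no measured step shows what such a change does, so neither direction can be favoured. In this assay the expected change is none beyond the scatter, with an estimated step (a 1.1-fold lower number from compound 1 to compound 3 (0.03 log units; within the scatter)) that stays small. For compound 3 the estimated value is 16000 nM with 8000 nM as the lower end and 30000 nM as the upper end of the expected range.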

Compound 3, half-maximal inhibitory concentration: 18800 nM
Compound 3: the middle estimate sits 1.2-fold (0.07 log units) below what was measured, and the stated range covers the measured number.
By their numbers in this assay, from the lowest: compounds 2, 1 and 3 (each within the scatter of the next).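

In this assay, 3-azidophenyl in place of 4-azidophenyl gives a 1.1-fold higher number from compound 1 to compound 3 (0.04 log units; within the scatter), on an aromatic carbon of the five-membered ring, next to the ring oxygen. Within the data shown here, this is the first direct reading of this change: the two compounds have the same atoms, joined differently, and this assay cannot tell the two arrangements apart. No measurement is available that would explain this result.

The compounds shown leave open whether another group on the phenyl ring at either of these two places, such as an amine or a carboxylic acid, would give a number that lies beyond the scatter. They also leave open whether 3-azidophenyl and 4-azidophenyl would remain indistinguishable on a different core.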